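The compounds below may be only part of what the source reports. "The series", "measured", "known", "first", "only" and "open" are said of these compounds alone.

Within the data shown here, the account opens with compound 1, `CC(C)(C)c1cn(C[C@H](O)[C@H]2OC(=O)C(OCc3ccccc3)=C2OCc2ccccc2)nn1`, the only member of this small set for which a functional assay on CFPAC-1 cells (Homo sapiens) for antiproliferative activity, read by MTT assay, with a stated time of 72 h (on this read-out lower numbers stand for stronger inhibition and higher numbers for weaker inhibition), returns a number: compound 1 gives 54900 nM. Two further compounds share the benzyloxy-bearing core but carry an aryl group on the five-membered aromatic ring with 3 nitrogen and join that ring to the core through an alkene rather than a hydroxyethyl linker. Compound 2, `COc1ccc(-c2cn(C/C=C3\OC(=O)C(OCc4ccccc4)=C3OCc3ccccc3)nn2)cc1`, reaches only the limit of this assay, > 100000 nM, which is a limit and not a number; it stands at the limit of > 100000 nM in this assay, at which 1 of the 3 values shown sits. Compound 3, `O=C1O/C(=C\Cn2cc(-c3cc(F)cc(F)c3)nn2)C(OCc2ccccc2)=C1OCc1ccccc1`, is reported as "not active" (no number reported), with no number at all.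

Compound 4, `O=C1O[C@H]([C@@H](O)Cn2cc(-c3cc(F)cc(F)c3)nn2)C(OCc2ccccc2)=C1OCc1ccccc1`, differs from compound 1 by 3,5-difluorophenyl in place of tert-butyl on an aromatic carbon. Among the measured compounds shown here, no step between measured compounds covers this change. Given that compound 3 carries the same 3,5-difluorophenyl group and is "not active" (no number reported), while compound 1 with tert-butyl gives 54900 nM, a weakening beyond the scatter is expected in this assay, a 1.8-fold higher number from compound 1 to compound 4 (0.26 log units; within the scatter). Compound 4 is therefore estimated at 100000 nM, within a range of 30000 nM to 300000 nM.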

Compound 4, half-maximal inhibitory concentration: 62400 nM
Estimate against measurement, compound 4: 1.6-fold (0.20 log units) above; low and high end bracket the measured number.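

Setting 3,5-difluorophenyl in place of tert-butyl on this aromatic carbon gives a 1.1-fold higher number from compound 1 to compound 4 (0.06 log units; within the scatter) in this assay, so the read-out does not separate the two groups at this position. Compound 3, which carries the same 3,5-difluorophenyl group, is reported as not active, whereas compound 4 gives 62400 nM in this assay, so that group does not by itself go with a missing number. Nothing measured here bears on why the two groups read alike.

On these data alone, it remains open whether any group at this place can bring the number far lower than these two values. An amine, a carboxylic acid or a longer chain on this aromatic carbon, or an unsubstituted phenyl, would test how far this level holds.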